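The source may report more compounds than this note shows. Statements on the series, on what has been measured and on what is new or still open speak of the compounds shown alone.

Compound 1 `OC[C@H]1CCC[C@@H](c2cccc3ccccc23)O1` gives 39.2% in a functional assay on the whole organism (Abdomen, strain Swiss albino) for inhibition, with Mus musculus as the target, in the writhing test, with a stated time of 30 min, at a dose of 30 mg/kg by the oral route; on this read-out lower numbers stand for less inhibition and higher numbers for more inhibition at the one dose given (going by the name of the read-out).
Compound 2 `CC(C)C(=O)OC[C@H]1C[C@@H](Cl)C[C@@H](c2cccc3ccccc23)O1` gives 38.4% in this assay.

Of the compounds shown here, two have been measured so far, and their numbers sit close together: compound 2 is the lower of the two, with compound 1 only slightly higher, a gap that lies within the usual scatter of this kind of measurement, so no order between them can be read from it. Compound 3 `OC[C@H]1C[C@@H](Cl)C[C@@H](c2cccc3ccccc23)O1` has not yet been measured. It differs from compound 2 in one place: hydrogen in place of isopropylcarbonyl on an oxygen on a saturated carbon. The ester side chain is cut back to a free hydroxymethyl group, which compound 1 also carries. Among the measured compounds shown here, no measured step between two compounds that differ in only one place is available, so the size of this change cannot be read from a neighbour. Since compound 1, with the free hydroxymethyl, gives 39.2% and compound 2 gives 38.4%, the expectation is a step of a number 0.6 percentage points higher from compound 2 to compound 3 (within the scatter) that stays within the scatter, with no clear direction. Compound 3 is therefore estimated at 39%, most likely between 25% and 52%.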

Compound 3, a percentage reported as inhibition, in the whole organism at one dose (the size of the read-out at that dose, not a potency): 87.5%
Beside the measured number, compound 3's estimate is 48.5 percentage points below it; measured number outside the range, above it.
By their numbers in this assay, from the lowest: compounds 2 and 1 (each within the scatter of the next); then compound 3.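

In this assay, the free hydroxyl on the hydroxymethyl group proves to matter: hydrogen in place of isopropylcarbonyl on that oxygen gives a number 49.1 percentage points higher from compound 2 to compound 3 (beyond the scatter). The saturated ring carbon is just as sensitive, since chloro in place of hydrogen there gives a number 48.3 percentage points higher from compound 1 to compound 3 (beyond the scatter). Compound 3 is the only one of these compounds that carries both the chloro group and the free hydroxymethyl group, and each single change that links it to compound 1 or compound 2 makes a large difference.

Nothing available here explains why these steps are so large. From the compounds shown here alone, it remains open whether fluoro or bromo could stand in for chloro on the saturated ring carbon, and whether an amine in place of the hydroxyl, or a smaller acetyl ester, would keep the gain.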